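A few compounds are considered here, and "the series" means these few. Any claim that something is new, unique, unknown or untested is made for them only; others in the source may bear on it.

Working notes on the series. Three measured compounds share one core and differ only in the group on one aromatic carbon. Compound 1 `CC(C)N(Cc1cccc(OCCCCCC(=O)O)c1)C(=O)c1ccc(-c2cccc(-c3ccccc3)c2)cc1` carries 3-phenylphenyl there, compound 2 `CC(C)N(Cc1cccc(OCCCCCC(=O)O)c1)C(=O)c1ccc(-c2ccco2)cc1` has furan-2-yl in its place, and compound 3 `COc1cccc(-c2ccc(C(=O)N(Cc3cccc(OCCCCCC(=O)O)c3)C(C)C)cc2)c1` carries 3-methoxyphenyl. All three were run in an ADME assay on Raji cells (Homo sapiens) for cytotoxicity, read by CellTiter-Glo and resazurin assay, with a stated time of 72 h; on this read-out lower numbers stand for an effect already at smaller amounts and higher numbers for an effect only at larger amounts of compound. In this assay compound 1 returns only a limit, > 26000 nM. Compound 2 likewise gives only a limit, > 26000 nM. Compound 3 too gives only a limit, > 20900 nM. The steps between them, a step that the two limits leave unreadable from compound 1 to compound 2, a step that the two limits leave unreadable from compound 1 to compound 3 and a step that the two limits leave unreadable from compound 2 to compound 3, cannot be sized; two of the three values sit at the limit of > 26000 nM in this assay, at which 2 of the 3 values shown sit, and one at the limit of > 20900 nM in this assay, at which 1 of the 3 values shown sits. Compound 3 thus stands at a limit, not at a number, level with the other two as far as can be read.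

Compound 4 `COc1cc(OC)cc(-c2ccc(C(=O)N(Cc3cccc(OCCCCCC(=O)O)c3)C(C)C)cc2)c1` differs from compound 3 by methoxy in place of hydrogen on an aromatic carbon. For the measured compounds named here, none of the measured steps can be read, so they give no direction for this change; what they do show is that three different substituents at this position all leave the read-out at its limit. Compound 4 is accordingly estimated at 30000 nM, with an expected range from 15000 nM to 60000 nM. This estimate implies a step that the limit leaves unreadable from compound 3 to compound 4, expected to be none beyond the scatter, with the result most likely reported again as a limit.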

Compound 4, half-maximal effective concentration: > 26000 nM
Compound 4: no number, only a limit; the forecaster's own chance of this, stated with the estimate: 85%; the middle value lies beyond the limit too.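

In this assay compound 4 returns only a limit, > 26000 nM. None of the steps from compound 1, compound 2 or compound 3 to compound 4 can be read. The compounds shown leave open whether any group at this aromatic carbon brings the read-out to a measurable number rather than a limit.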